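A few compounds are considered here, and "the series" means these few. Any claim that something is new, unique, unknown or untested is made for them only; others in the source may bear on it.

Compound 1 `COc1ccc(N)c(C2=NN(C(=O)C3CC3)CC2)c1` gives 19.9% in an assay on isolated protein for inhibition of Nitric oxide synthase, inducible (Homo sapiens), with a stated time of 30 min, tested at 1 mM; a lower number here means less inhibition, a higher number more inhibition at the concentration tested (going by the name of the read-out).
Compound 2 `COc1ccc(N)c(C2=NN(C(=O)c3ccccc3)CC2)c1` gives 12.2% in this assay.
Compound 3 `Nc1ccccc1C1=NN(C(=O)C2CC2)CC1` gives 14.8% in this assay.

The three measured compounds differ from one another in single places. The change from compound 1 to compound 2 is phenyl in place of cyclopropyl on a carbonyl carbon and gives a number 7.7 percentage points lower from compound 1 to compound 2 (within the scatter). Compound 3 differs from compound 1 by hydrogen in place of methoxy on an aromatic carbon, with a number 5.1 percentage points lower from compound 1 to compound 3 (within the scatter). Compound 3 and compound 2 are close to each other, their two values differing by less than the usual scatter. Compound 4 `Nc1ccccc1C1=NN(C(=O)c2ccccc2)CC1` has not yet been measured in this assay. It stands to compound 3 as compound 2 stands to compound 1: the change is phenyl in place of cyclopropyl on a carbonyl carbon, and it occurs twice among the compounds shown. The two cores differ in the way described for compound 3 against compound 1. The surroundings of the changed carbonyl carbon are the same in both pairs, so this is the same change. The step from compound 3 to compound 4 is expected to be a number 5.8 percentage points lower from compound 3 to compound 4 (within the scatter); this expectation rests on the earlier step of the same kind, a number 7.7 percentage points lower from compound 1 to compound 2 (within the scatter). Compound 4 is therefore expected to give about 9%, within a range from 0% to 22%.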

Compound 4, a percentage reported as inhibition, at one concentration (the size of the read-out at that concentration, not a potency): 8.7%
For compound 4 the middle estimate is 0.3 percentage points above the measured one; the measured number falls inside the stated range.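

In this assay, phenyl in place of cyclopropyl on a carbonyl carbon carried from one core to the other with no difference beyond the scatter: the same change on two cores in this assay, a number 7.7 percentage points lower (within the scatter) from compound 1 to compound 2 and a number 6.1 percentage points lower (within the scatter) from compound 3 to compound 4, 1.6 percentage points apart, within the scatter of two such steps

Hydrogen in place of methoxy on an aromatic carbon, here a number 3.5 percentage points lower from compound 2 to compound 4 (within the scatter), behaved in the same way: the same change on two cores in this assay, a number 5.1 percentage points lower (within the scatter) from compound 1 to compound 3 and a number 3.5 percentage points lower (within the scatter) from compound 2 to compound 4, 1.6 percentage points apart, within the scatter of two such steps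

Yet the new step of a number 6.1 percentage points lower from compound 3 to compound 4 (within the scatter) and all the other steps lie within the scatter, so the agreement shows only that neither change gave a readable effect on either core; it does not show that a real effect of fixed size transfers, and readings at one concentration say nothing about potency.

The compounds shown leave open whether another group on the carbonyl carbon, such as a longer chain or an amine, would move the number beyond the scatter. They also leave open what a carboxylic acid in place of the methoxy on the aromatic carbon would give in this assay.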